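Adding a methoxy to the phenol compound 2

This account rests on a few compounds, and the source may have more. Where it says the series, first, only, none or still open, it means among the compounds named here.

Measured in a functional assay on DU-145 cells (Homo sapiens) for cytotoxicity, read by sulforhodamine B assay, with a stated time of 48 h; on this read-out higher numbers stand for weaker inhibition and lower numbers for stronger inhibition:
compound 1 `COc1ccc(C2=NO[C@]3(C2)C(=O)O[C@@H]2[C@H]3CC[C@H](C)[C@]3(O)C=CC(=O)[C@@]23C)cc1`: 20000 nM
compound 2 `C[C@H]1CC[C@@H]2[C@@H](OC(=O)[C@]23CC(c2ccc(O)cc2)=NO3)[C@]2(C)C(=O)C=C[C@@]12O`: 93000 nM

Of the two measured compounds, compound 2 carries the highest number, 93000 nM, so it is the weaker inhibitor of the pair. Compound 3 `COc1cc(C2=NO[C@]3(C2)C(=O)O[C@@H]2[C@H]3CC[C@H](C)[C@]3(O)C=CC(=O)[C@@]23C)ccc1O` keeps its hydroxy group and adds one substituent: methoxy in place of hydrogen on an aromatic carbon. This is methoxy in place of hydrogen on an aromatic carbon, ortho to a hydroxy group, turning 4-hydroxyphenyl into 4-hydroxy-3-methoxyphenyl.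

Among the compounds with values here, only one measured step bears on this change: a 4.7-fold higher number from compound 1 to compound 2 (0.67 log units; beyond the scatter), a modest step beyond the scatter, with hydrogen in place of methyl on an oxygen. It concerns a different place on the ring, so it is only a loose guide. In this assay a modest move toward a lower number is expected, somewhat smaller than that step. The expected change is a 1.9-fold lower number from compound 2 to compound 3 (0.27 log units; within the scatter). Compound 3 is estimated at 50000 nM, with an expected range of 20000 nM to 120000 nM.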

Compound 3, half-maximal inhibitory concentration: 71000 nM
For compound 3 the middle estimate is 1.4-fold (0.15 log units) below the measured one; the range from low to high includes it.
By their numbers in this assay, from the lowest: compound 1; then compounds 3 and 2 (each within the scatter of the next).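

In this assay, methoxy on the aromatic carbon ortho to the hydroxy group gives a 1.3-fold lower number from compound 2 to compound 3 (0.12 log units; within the scatter), so this addition does not separate the two compounds beyond the usual scatter. The other new step, a 3.6-fold higher number from compound 1 to compound 3 (0.55 log units; beyond the scatter), shows that 4-hydroxy-3-methoxyphenyl does not match the lower number held by the 4-methoxyphenyl of compound 1. Nothing at hand accounts for the methoxy leaving the number within the scatter.

The compounds shown leave open whether another group at this place, such as an amine or a chlorine atom, would move the number beyond the scatter. They also leave open how this methoxy would behave with the hydroxy group replaced by a longer ether such as ethoxy.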